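The source may report more compounds than this note shows. Statements on the series, on what has been measured and on what is new or still open speak of the compounds shown alone.

Working notes on the series. Among the compounds with values here, in a functional assay on SK-OV-3 cells (Homo sapiens) (on this read-out lower numbers stand for stronger inhibition of growth and higher numbers for weaker inhibition of growth), compound 2 `O=S(=O)(/C=C/c1ccc(C(F)(F)F)cc1F)Cc1ccc(Nc2ncnc3ccc(Br)cc23)cc1` gives 5000 nM, the highest of the three numbers so far. Compound 3 `O=S(=O)(/C=C/c1ccc(F)cc1F)Cc1ccc(Nc2ncnc3ccc(Br)cc23)cc1` gives 2000 nM, and compound 1 `O=S(=O)(/C=C/c1ccc(Cl)cc1Cl)Cc1ccc(Nc2ncnc3ccc(Br)cc23)cc1` gives 1000 nM.

Compound 4 `O=S(=O)(/C=C/c1ccc(C(F)(F)F)cc1F)Cc1ccc(Nc2ncnc3cc(Cl)ccc23)cc1` keeps the 2-fluoro-4-(trifluoromethyl)phenyl group of compound 2 and differs at one place: a group of 11 heavy atoms (8 carbon, 2 nitrogen, 1 chlorine; one six-membered aromatic ring of carbon only, one six-membered aromatic ring with 2 hetero atoms) in place of a group of 11 heavy atoms (8 carbon, 2 nitrogen, 1 bromine; one six-membered aromatic ring of carbon only, one six-membered aromatic ring with 2 hetero atoms), on a nitrogen on an aromatic ring. The entering group is 7-chloroquinazolin-4-yl, and the exchange sits on a nitrogen on an aromatic ring.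

Within the data shown here, no measured step touches this group. The three available steps, a 5.0-fold higher number from compound 1 to compound 2 (0.70 log units; beyond the scatter), a 2.0-fold higher number from compound 1 to compound 3 (0.30 log units; within the scatter) and a 2.5-fold lower number from compound 2 to compound 3 (0.40 log units; beyond the scatter), all change the phenyl group on the double-bonded chain carbon. They therefore give no direction for this exchange and show only how far the numbers have moved within the series. With no direct evidence, no step beyond the scatter is expected, and the largest measured step, a 5.0-fold higher number from compound 1 to compound 2 (0.70 log units; beyond the scatter), argues for a wide range. The expected step is no change at the digits printed from compound 2 to compound 4 (within the scatter). For compound 4 the estimated value is 5000 nM, with an expected range of 1500 nM to 15000 nM.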

Compound 4, concentration for 50% growth inhibition: > 100000 nM
Compound 4 ended at the assay's limit (the forecaster's own chance of this, stated with the estimate: 15%); middle value at least 20-fold (1.30 log units) away from the limit.
By their numbers in this assay, from the lowest: compounds 1 and 3 (each within the scatter of the next); then compound 2. At a limit, above all of these: compound 4.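

this assay Compound 4 stands at a limit of the assay, > 100000 nM, and this is not a number: the limit of > 100000 nM in this assay, at which 1 of the 4 values shown sits.

Within the data shown here, the exchange to 7-chloroquinazolin-4-yl on the nitrogen gives an at least 20-fold higher number from compound 2 to compound 4 (1.30 log units; beyond the scatter), the first measured step at this place. Growth inhibition therefore responds to this exchange, and the step is larger than the largest one among the phenyl changes, a 5.0-fold higher number from compound 1 to compound 2 (0.70 log units; beyond the scatter).

The single step changes the halogen and its place on the group together, so the compounds shown do not separate the two. Also open, as far as these compounds go, are whether a 7-bromoquinazolin-4-yl group, or an amine in place of the chlorine, would restore growth inhibition, and whether the 2,4-dichlorophenyl group of compound 1 would respond to this exchange in the same way.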